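Sulfonamide variation in a chloro-phenoxyacetic acid series

The compounds below may be only part of what the source reports. "The series", "measured", "known", "first", "only" and "open" are said of these compounds alone.

Measured so far in an assay on CHO cells for displacement of a labelled ligand from prostaglandin D2 receptor 2 (Homo sapiens), read by scintillation counting; on this read-out lower numbers stand for stronger inhibition and higher numbers for weaker inhibition:
- compound 1, `Cc1ccc(S(=O)(=O)Cc2ccccc2)cc1C#Cc1cc(Cl)ccc1OCC(=O)O`, gives 5 nM
- compound 2, `COCCNS(=O)(=O)c1ccc(C)c(C#Cc2cc(Cl)ccc2OCC(=O)O)c1`, gives 3.6 nM
- compound 3, `Cc1ccc(S(=O)(=O)NC(C)C)cc1C#Cc1cc(Cl)ccc1OCC(=O)O`, gives 3.4 nM

Compound 3 shows the lowest number of the three, but its gaps to the others are small: a 1.5-fold lower number from compound 1 to compound 3 (0.17 log units; within the scatter) and a 1.1-fold lower number from compound 2 to compound 3 (0.02 log units; within the scatter) both stay within the scatter, so no order among compounds 1, 2 and 3 can be claimed.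

Compound 4, `Cc1ccc(S(=O)(=O)N(C)CCCN(C)C)cc1C#Cc1cc(Cl)ccc1OCC(=O)O`, is not yet measured. It differs from compound 3 by (3-(dimethylamino)propyl)(methyl)amino in place of isopropylamino on a sulfonyl sulfur. For the measured compounds named here, the steps that bear on this are the two sulfonyl substituent changes already seen, a 1.4-fold lower number from compound 1 to compound 2 (0.14 log units; within the scatter) and a 1.5-fold lower number from compound 1 to compound 3 (0.17 log units; within the scatter), each within the scatter. On that basis no step beyond the scatter is expected in this assay, and the expected step is a 1.2-fold higher number from compound 3 to compound 4 (0.07 log units; within the scatter). Compound 4 is therefore estimated at 4 nM, with a range from 1.5 nM to 11 nM.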

Compound 4, inhibition constant: 287 nM
Beside the measured number, compound 4's estimate is 72-fold (1.86 log units) below it, outside the stated range (above it).
By their numbers in this assay, from the lowest: compounds 3, 2 and 1 (each within the scatter of the next); then compound 4.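

In this assay, for the compounds shown here, this position on the sulfonyl sulfur proves far less permissive than the earlier compounds suggested: (3-(dimethylamino)propyl)(methyl)amino brings an 84-fold higher number from compound 3 to compound 4 (1.93 log units; beyond the scatter) and an 80-fold higher number from compound 2 to compound 4 (1.90 log units; beyond the scatter) as well as a 57-fold higher number from compound 1 to compound 4 (1.76 log units; beyond the scatter) on the same core. Benzyl, (2-methoxyethyl)amino and isopropylamino had stayed within the scatter of one another. Nothing measured here gives a cause for the step.

On these data alone, compound 4 carries the methyl on the sulfonamide nitrogen and the terminal dimethylamino together, so which of them matters stays open. A 3-(dimethylamino)propylamino group without that methyl, or a plain dimethylamino group, would separate the two.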